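Trifluoromethyl for Dimethylamino on the Shared Core

This account rests on a few compounds, and the source may have more. Where it says the series, first, only, none or still open, it means among the compounds named here.

Measured compounds:
compound 1 `COc1cc(-c2ccnc3cc(-c4ccc(N(C)C)cc4)nn23)cc(OC)c1OC` — 2050 nM
compound 2 `COc1cc(-c2ccnc3cc(-c4cccc5c4ccn5CO)nn23)cc(OC)c1OC` — 861 nM
compound 3 `COc1cc(-c2ccnc3cc(-c4cn(CO)c5ccccc45)nn23)cc(OC)c1OC` — 128 nM

Of the compounds shown here, three built on the same core have been tested in a functional assay on HCT-116 cells (Homo sapiens) for inhibition, read by CCK-8 assay, with a stated time of 48 h; on this read-out lower numbers stand for stronger inhibition and higher numbers for weaker inhibition. Compound 1 gives 2050 nM, the highest number of the three. The nearest is compound 2 at 861 nM, a gap beyond the usual scatter, and the furthest is compound 3 at 128 nM, far beyond it. Compound 1 therefore stands as the weakest of the measured set.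

Compound 4 `COc1cc(-c2ccnc3cc(-c4ccc(C(F)(F)F)cc4)nn23)cc(OC)c1OC` has not yet been measured. It differs from compound 1 in one place: trifluoromethyl in place of dimethylamino on an aromatic carbon. For the measured compounds named here, no measured pair shows this exchange, so nothing in the data fixes its direction or size. Compound 4 is expected to stay close to compound 1 in this assay, with at most a small step, a 1.5-fold higher number from compound 1 to compound 4 (0.17 log units; within the scatter), that may well lie within the scatter. The estimate for compound 4 is 3000 nM, with a range from 800 nM to 12000 nM.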

Compound 4, half-maximal inhibitory concentration: 1860 nM
For compound 4 the middle estimate is 1.6-fold (0.21 log units) above the measured one; measured number inside the range.
By their numbers in this assay, from the lowest: compound 3; then compound 2; then compounds 4 and 1 (each within the scatter of the next).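

In this assay, for the compounds shown here, the change from 4-(dimethylamino)phenyl to 4-(trifluoromethyl)phenyl gives a 1.1-fold lower number from compound 1 to compound 4 (0.04 log units; within the scatter), the first measured reading of this exchange on the shared core. At this aromatic carbon, a group with one hydrogen-bond acceptor and a group with none therefore cannot be told apart by this read-out, although the two groups share only a single kind of atom, carbon. Nothing available explains why the two groups read alike.

From the compounds shown here alone, whether a primary amine, a carboxylic acid or a longer alkyl chain on the same aromatic carbon would also leave the number in place remains open. So does whether this exchange would read the same way on a core carrying a different aromatic group.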